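Hydrogen in Place of Methoxy: From Compound 2 to Compound 4

This account rests on a few compounds, and the source may have more. Where it says the series, first, only, none or still open, it means among the compounds named here.

Measured compounds:
compound 1, `O=S(=O)(c1ccccc1)c1cn(C2CCNC2)c2ccccc12`: 60 nM
compound 2, `COc1ccc2c(c1)c(S(=O)(=O)c1cccc(F)c1)cn2C1CCCNC1`: 73 nM
compound 3, `COc1ccc2c(c1)c(S(=O)(=O)c1cccc(F)c1)cn2C1CCCN(C)C1`: "not determined" (no result reported)

Three compounds share a core in which an indole carries a sulfonyl-linked aromatic ring and a saturated nitrogen-containing ring on the ring nitrogen. In a functional assay on HeLa cells for agonist activity at 5-hydroxytryptamine receptor 6 (Homo sapiens), read by cAMP accumulation and immunoassay, with a stated time of 10 min (a lower number here means that less compound is needed, a higher number that more compound is needed for the effect), compound 1 gives 60 nM. In this assay compound 2 gives 73 nM. Compound 2 has the higher of the two numbers, but the gap to compound 1 lies within the usual scatter of the measurement, so the two cannot be ordered. In this assay compound 3 gives "not determined" (no result reported).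

Compound 4, `O=S(=O)(c1cccc(F)c1)c1cn(C2CCCNC2)c2ccccc12`, differs from compound 2 in one place: hydrogen in place of methoxy on an aromatic carbon. The remaining parts of compound 2, the fluorine on the sulfonyl-linked ring and the six-membered saturated amine, are kept. Compound 1, which also lacks the methoxy group, gives a number close to that of compound 2, so the methoxy group does not appear to set the activity within this small set. The step in this assay from compound 2 to compound 4 is therefore expected to be small and without a clear direction, that is, none beyond the scatter, as a 1.0-fold lower number from compound 2 to compound 4 (0.02 log units; within the scatter) expresses. Compound 4 is estimated to give 70 nM in this assay, with a range from 25 nM to 200 nM.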

Compound 4, half-maximal effective concentration: 56 nM
Estimate against measurement, compound 4: 1.3-fold (0.10 log units) above; the range from low to high includes it.
By their numbers in this assay, from the lowest: compounds 4, 1 and 2 (each within the scatter of the next).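

In this assay, within the data shown here, hydrogen in place of methoxy on this aromatic carbon gives a 1.3-fold lower number from compound 2 to compound 4 (0.12 log units; within the scatter) and so provides the first comparison in which this group is the only thing that differs. The earlier compounds shown here could not show this, since compound 1 differs from compound 2 in more than one place and compound 3 has no number to set against compound 2. With the fluorine on the sulfonyl-linked ring and the six-membered saturated amine kept, the pair shows that this position can carry either methoxy or hydrogen without a difference that can be read, and nothing available explains this result.

What the compounds shown leave open is whether this position stays as undemanding with other groups on the same aromatic carbon, such as a chlorine atom, a hydroxy group, an amine, a carboxylic acid or a longer alkoxy chain like butoxy. They also leave open whether the same replacement gives so small a step with a different sulfonyl-linked ring or another saturated amine, as this single pair speaks only for the one setting in which it was read.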